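Replacing 3-methoxyphenyl with 4-fluorophenyl on compound 2

A few compounds are considered here, and "the series" means these few. Any claim that something is new, unique, unknown or untested is made for them only; others in the source may bear on it.

Compound 1 `COc1cc(O)c(C(=O)/C=C/c2ccc(F)cc2)c(OC)c1`: > 20000 nM (a limit of the assay)
Compound 2 `COc1cccc(/C=C/C(=O)c2c(OC)cc(OC)cc2OC)c1`: 8900 nM

Only these two compounds have been measured. Among the compounds with values here, in a functional assay on Huh-7 cells (Homo sapiens) for cytotoxicity, with a stated time of 48 h (on this read-out lower numbers stand for stronger inhibition and higher numbers for weaker inhibition), compound 2 gives 8900 nM, the only actual number so far. In this assay compound 1 gives > 20000 nM, which is a limit and not a number.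

Compound 3 `COc1cc(OC)c(C(=O)/C=C/c2ccc(F)cc2)c(OC)c1` differs from compound 2 by having 4-fluorophenyl in place of 3-methoxyphenyl on a double-bonded chain carbon bound to a double-bonded chain carbon. Within the data shown here, no measured step tests this change, so the expectation rests on compound 2 at 8900 nM alone. No step beyond the scatter is expected in this assay, and any drift is expected to lean toward weaker inhibition. The estimated move is a 1.3-fold higher number from compound 2 to compound 3 (0.13 log units; within the scatter). For compound 3 the estimated value is 12000 nM, with an expected range from 5000 nM to 25000 nM.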

Compound 3, half-maximal inhibitory concentration: 14600 nM
Compound 3: middle estimate off by 1.2-fold (0.09 log units), on the low side, within the range that was stated.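

In this assay, 4-fluorophenyl in place of 3-methoxyphenyl on a double-bonded chain carbon bound to a double-bonded chain carbon gives a 1.6-fold higher number from compound 2 to compound 3 (0.21 log units; within the scatter), so this position now has a measured step, and that step does not go beyond the scatter. Methyl in place of hydrogen on an oxygen on an aromatic ring gives an at least 1.3-fold lower number from compound 1 to compound 3 (0.13 log units; that floor lies within the scatter), a floor and not a full step. Compound 1 stands at a limit of the assay and not at a number, so the true size of this second step cannot be read: the limit of > 20000 nM in this assay, at which 1 of the 3 values shown sits.

From the compounds shown here alone, whether any other group at this position, such as an aminophenyl or a carboxyphenyl, would give a step beyond the scatter stays open. So does whether a longer chain in place of methyl on that oxygen would change the number in this assay.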